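The compounds below may be only part of what the source reports. "The series", "measured", "known", "first", "only" and "open" are said of these compounds alone.

Compound 1 `Cc1nnc2ccc(N[C@H]3CC[C@@H](Nc4ccnc(C(F)(F)F)n4)CC3)nn12` and compound 2 `FC(F)(F)c1nccc(N[C@H]2CC[C@@H](Nc3ccc4nnc(C5CC5)n4n3)CC2)n1` share a core and differ in one group. In an ADME assay on microsomes from liver (Homo sapiens) for metabolic stability, read by LC-MS (on this read-out lower numbers stand for slow clearance and higher numbers for fast clearance), compound 1 gives < 3 mL.min-1.g-1, which is a limit of the assay and not a number. Compound 2 gives < 3 mL.min-1.g-1, which is also a limit and not a number. Compound 2 therefore has no exact clearance to start from, and the whole picture so far is the limit of < 3 mL.min-1.g-1 in this assay, at which 2 of the 2 values shown sit.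

Compound 3 `FC(F)(F)c1nccc(N[C@H]2CC[C@@H](Nc3ccc4nnc(C(F)(F)F)n4n3)CC2)n1` carries the next change, (trifluoromethyl in place of cyclopropyl on an aromatic carbon). In words, this is trifluoromethyl in place of cyclopropyl on an aromatic carbon, on a five-membered aromatic ring with 3 nitrogen, between two ring nitrogen atoms.

For the measured compounds named here, the only measured step that bears on this is a step that the two limits leave unreadable from compound 1 to compound 2, at the same carbon, and it has no readable size. With both sides of that step at the limit, no step beyond the usual scatter is expected in this assay, and no direction can be favoured. The expected step is a number no lower from compound 2 to compound 3 (the limit leaves the size open). For compound 3 the estimated value is 3 mL.min-1.g-1, with an expected range of 1.5 mL.min-1.g-1 to 6 mL.min-1.g-1.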

Compound 3, intrinsic clearance in microsomes: < 3 mL.min-1.g-1
Compound 3 ended at the assay's limit; the forecaster's own chance of this, stated with the estimate: 75%; the middle value sits exactly at the limit.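

In this assay compound 3 gives < 3 mL.min-1.g-1 as a limit of the assay and not a number. For the compounds shown here, no step between compound 1, compound 2 and compound 3 can be read, because all three share one result: the limit of < 3 mL.min-1.g-1 in this assay, at which 3 of the 3 values shown sit. Going by these compounds, whether methyl, cyclopropyl and trifluoromethyl on this aromatic carbon differ in clearance at all, and by how much, stays open.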